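Amide substituent changes in an oral rat inhibition series

The compounds below may be only part of what the source reports. "The series", "measured", "known", "first", "only" and "open" are said of these compounds alone.

Compound 1, `NC(=O)/C=C1\CCc2c(F)cccc21`, gives 40% in a functional assay on the whole organism with Rattus norvegicus as the target, at a dose of 20 mg/kg by the oral route; a higher number here means more inhibition at the dose given (going by the name of the read-out), a lower number less inhibition.
Compound 2, `O=C(/C=C1\CCc2ccc(F)cc21)NCC1CC1`, gives 0%.
Compound 3, `O=C(/C=C1\CCc2ccc(F)cc21)NCCO`, gives 42%.

Compound 3 holds the highest of the three numbers; compound 1 lies within the scatter of it, compound 2 far below. Among the measured compounds shown here, the only one-place step measured is a number 42 percentage points higher from compound 2 to compound 3 (beyond the scatter), where hydroxymethyl replaced cyclopropyl on a saturated chain carbon bound to an amide-type nitrogen. Compound 4, `CCNC(=O)/C=C1\CCc2ccc(F)cc21`, differs from compound 3 by hydrogen in place of hydroxy on a saturated chain carbon, two bonds along the chain from an amide-type nitrogen. For the measured compounds named here, no measured step removes a hydroxy, so that step gives only indirect guidance. Compound 4 keeps a short chain, unlike compound 2, and is expected to give a lower number, an estimated 28% (range 5% to 55%), that is an expected step of a number 14 percentage points lower from compound 3 to compound 4 (beyond the scatter).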

Compound 4, a percentage reported as inhibition, in the whole organism at one dose (the size of the read-out at that dose, not a potency): 45%
For compound 4 the middle estimate is 17 percentage points below the measured one; low and high end bracket the measured number.
By their numbers in this assay, from the lowest: compound 2; then compounds 1, 3 and 4 (each within the scatter of the next).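

In this assay, hydrogen in place of hydroxy gives a number 3 percentage points higher from compound 3 to compound 4 (within the scatter), so the hydroxy is not required at this position to hold the read-out. Methyl in place of cyclopropyl gives a number 45 percentage points higher from compound 2 to compound 4 (beyond the scatter), so the low number of compound 2 is also lifted by a change that introduces no hydroxy. No measured evidence bears on the reason for either step.

As far as these compounds go, whether an amine or a carboxylic acid at this position would hold the read-out remains open. So does whether a longer chain would match compound 4 or fall towards compound 2.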